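Ethyl in Place of Trifluoromethyl on a Dopamine Receptor Agonist

A few compounds are considered here, and "the series" means these few. Any claim that something is new, unique, unknown or untested is made for them only; others in the source may bear on it.

Measured so far:
compound 1 `Cc1cc(C)cc(NC(=O)CN2CCC(c3cccc[n+]3[O-])CC2)c1` gives 76% in a functional assay on HEK293 cells for agonist activity at D(4) dopamine receptor (Homo sapiens), read by FLIPR; on this read-out higher numbers stand for larger maximal responses and lower numbers for smaller maximal responses
compound 2 `CSc1cccc(NC(=O)CN2CCC(c3cccc[n+]3[O-])CC2)c1` gives 56% in this assay
compound 3 `O=C(CN1CCC(c2cccc[n+]2[O-])CC1)Nc1cccc(C(F)(F)F)c1` gives 75% in this assay

Compound 3 stands second highest of the three numbers. Its value and that of compound 1 lie within the scatter of each other, so the two cannot be ordered. Compound 2 is clearly lower, as the step of a number 19 percentage points higher from compound 2 to compound 3 (beyond the scatter) shows.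

Compound 4 `CCc1cccc(NC(=O)CN2CCC(c3cccc[n+]3[O-])CC2)c1` is not yet measured. It differs from compound 3 in one place: ethyl in place of trifluoromethyl on an aromatic carbon. The step that bears on this most directly is a number 19 percentage points higher from compound 2 to compound 3 (beyond the scatter), which also exchanged the group on that aromatic carbon; the step of a number 20 percentage points lower from compound 1 to compound 2 (beyond the scatter) was of similar size. Both steps were modest. Ethyl and trifluoromethyl share the counted features of no donor, no acceptor and no charge, so the change for compound 4 is expected to be at most modest, and most likely no step beyond the scatter, giving an estimated a number 7 percentage points lower from compound 3 to compound 4 (within the scatter). Compound 4 is therefore estimated at 68%, with a range from 52% to 84%.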

Compound 4, largest response reached (reported as efficacy), in percent of the reference or control that the assay uses: 62%
The estimate for compound 4 lay 6 percentage points above the measured number; the measured number falls inside the stated range.
By their numbers in this assay, from the lowest: compounds 2 and 4 (each within the scatter of the next); then compounds 3 and 1 (each within the scatter of the next).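

Trifluoromethyl and ethyl match in the counted donors, acceptors and charge, yet this exchange on the aromatic carbon is not neutral in this assay: the result is a number 13 percentage points lower from compound 3 to compound 4 (beyond the scatter). Ethyl and methylsulfanyl at this place cannot be told apart, with a number 6 percentage points higher from compound 2 to compound 4 (within the scatter), whereas the single ethyl group does not match the 3,5-dimethylphenyl arrangement, with a number 14 percentage points lower from compound 1 to compound 4 (beyond the scatter). No measured property of these groups is available to explain these steps.

The compounds shown leave open how an amine or a carboxylic acid on this aromatic carbon would behave on this read-out. They also leave open whether a longer chain such as propyl would continue the step seen with ethyl or reverse it.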